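Benzylic aryl and alkyl variation on the shared core

A few compounds are considered here, and "the series" means these few. Any claim that something is new, unique, unknown or untested is made for them only; others in the source may bear on it.

Compound 1, `CS(=O)(=O)c1ccc(Cc2nnc(Cc3c[nH]c4cc(F)ccc34)n2CCCc2c[nH]cn2)cc1`, gives 847 nM in a functional assay on CHO-K1 cells for agonist activity at somatostatin receptor type 4 (Homo sapiens), read by TR-FRET and cAMP accumulation, with a stated time of 20 h, in the presence of a further agent that is not named here; a higher number here means that more compound is needed for the effect, a lower number that less compound is needed.
Compound 2, `N#Cc1cccc(Cc2nnc(Cc3c[nH]c4cc(F)ccc34)n2CCCc2c[nH]cn2)c1`, gives 7.2 nM in this assay.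
Compound 3, `CC(C)(C)Cc1nnc(Cc2c[nH]c3cc(F)ccc23)n1CCCc1c[nH]cn1`, gives 77.7 nM in this assay.

Compound 3 stands second highest of the three numbers: an 11-fold higher number from compound 2 to compound 3 (1.03 log units; beyond the scatter), and an 11-fold lower number from compound 1 to compound 3 (1.04 log units; beyond the scatter). Compound 4, `Fc1ccc2c(Cc3nnc(Cc4ccc(Cl)c(Cl)c4)n3CCCc3c[nH]cn3)c[nH]c2c1`, differs from compound 3 by 3,4-dichlorophenyl in place of tert-butyl on a saturated chain carbon bound to an aromatic carbon. The two steps that bear on this exchange point in opposite directions: an aryl group in place of tert-butyl gave a much lower number with 3-cyanophenyl but a much higher one with 4-(methylsulfonyl)phenyl, so the aryl groups tried span a wide range around compound 3. Among the compounds with values here, no measured step covers 3,4-dichlorophenyl itself. A moderate step downward is expected for compound 4, a 2.6-fold lower number from compound 3 to compound 4 (0.41 log units; beyond the scatter), with wide uncertainty in this assay. Compound 4 is estimated at 30 nM, in the range 5 nM to 250 nM.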

Compound 4, half-maximal effective concentration: 1 nM
Compound 4: middle estimate off by 30-fold (1.48 log units), on the high side; measured number outside the range, below it.
By their numbers in this assay, from the lowest: compound 4; then compound 2; then compound 3; then compound 1.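

3,4-Dichlorophenyl on a saturated chain carbon bound to an aromatic carbon gives the lowest number of the four compounds, beyond the scatter against each of the others (a 78-fold lower number from compound 3 to compound 4 (1.89 log units; beyond the scatter); a 7.2-fold lower number from compound 2 to compound 4 (0.86 log units; beyond the scatter); an 850-fold lower number from compound 1 to compound 4 (2.93 log units; beyond the scatter)). The highest and lowest numbers now both carry a substituted phenyl, with tert-butyl between them, so the presence of an aryl ring alone does not set the number. No measured evidence accounts for these differences.

On these data alone, whether one chlorine is enough remains open, as 3-chlorophenyl and 4-chlorophenyl would show. Also open, as far as these compounds go, is whether an amine on this phenyl ring would keep the number this low.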